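A few compounds are considered here, and "the series" means these few. Any claim that something is new, unique, unknown or untested is made for them only; others in the source may bear on it.

Working notes, antiproliferative series

Read-out used throughout: a functional assay on MDA-MB-231 cells (Homo sapiens) for antiproliferative activity, read by sulforhodamine B assay, with a stated time of 48 h; on this read-out higher numbers stand for weaker inhibition and lower numbers for stronger inhibition. Measured so far:

compound 1, `COc1cc(C(=O)/C=C\Nc2ccc(-c3nc4cc(OC)c(OC)c(OC)c4s3)cc2C)cc([N+](=O)[O-])c1OC`: 12800 nM
compound 2, `COc1ccc(C(=O)/C=C\Nc2ccc(-c3nc4cc(OC)c(OC)c(OC)c4s3)cc2C)cc1[N+](=O)[O-]`: 12400 nM
compound 3, `COc1cc(C(=O)/C=C\Nc2ccc(-c3nc4cc(OC)c(OC)c(OC)c4s3)cc2)cc([N+](=O)[O-])c1OC`: 9800 nM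

The three numbers lie close together. The step of a 1.0-fold lower number from compound 1 to compound 2 (0.01 log units; within the scatter) belongs to the change (hydrogen in place of methoxy on an aromatic carbon). The two cores differ by hydrogen in place of methyl on an aromatic carbon, which gives the step of a 1.3-fold lower number from compound 1 to compound 3 (0.12 log units; within the scatter). Neither step separates from the other, so nothing among compound 1, compound 2 and compound 3 can be ranked.

Compound 4, `COc1cc(OC)c2sc(-c3ccc(N/C=C\C(=O)c4cc(OC)c(OC)c([N+](=O)[O-])c4)cc3)nc2c1`, is not yet measured. It differs from compound 3 by hydrogen in place of methoxy on an aromatic carbon. Among the compounds with values here, this is the same kind of change as the one from compound 1 to compound 2, but not the same change: in compound 4 the hydrogen enters on a ring that is part of a fused or bridged system of two rings, ortho to two methoxy groups, meta to a fused ring and para to a fused ring, whereas in compound 2 the place is ortho to a methoxy group, meta to a large group and meta to a nitro group. Within the data shown here, the only measured precedent for removing a methoxy group is a 1.0-fold lower number from compound 1 to compound 2 (0.01 log units; within the scatter), which changed nothing beyond the scatter. On that basis a step of a 1.3-fold higher number from compound 3 to compound 4 (0.12 log units; within the scatter) is expected, with a wide range because the place differs. Compound 4 is estimated at 13000 nM, expected between 6000 nM and 30000 nM.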

Compound 4, half-maximal inhibitory concentration: 3060 nM
The estimate for compound 4 lay 4.2-fold (0.63 log units) above the measured number; measured number outside the range, below it.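

In this assay, hydrogen in place of methoxy on an aromatic carbon of the ring that is part of a fused or bridged system of two rings gives a 3.2-fold lower number from compound 3 to compound 4 (0.51 log units; beyond the scatter). Set beside the earlier removal of a methoxy group, this shows that the change does not carry over from one core to the other with a single size of step: the same change on two cores in this assay, a 1.0-fold lower number (0.01 log units; within the scatter) from compound 1 to compound 2 and a 3.2-fold lower number (0.51 log units; beyond the scatter) from compound 3 to compound 4, 3.1-fold (0.49 log units) apart, beyond the scatter of two such steps The comparison does not show why the steps differ: they remove a methoxy group at different places, on cores that also differ by a methyl group, and with only one pair on each core, the effect of the place cannot be told apart from that of the core, nor can any rule for a further core be drawn.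

The compounds shown leave open whether the same removal on the fused ring would give a comparable step with the methyl group present, as on the core of compound 1. Also open, from the compounds shown here alone, is what a fluorine atom, a hydroxyl group or an ethoxy group would give at that place, and what an amine would give in place of the nitro group.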